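The source may hold more compounds than are shown below. What is called first, only, known or untested is meant among the compounds shown, and "the series" means these compounds.

Measured compounds:
- compound 1, `Cn1c(-c2ccc(Br)cc2)cnc1NC(=O)c1ccc(F)cc1`, in a toxicity assay on THP-1 cells (Homo sapiens) for inhibition (on this read-out lower numbers stand for higher toxicity in this test and higher numbers for lower toxicity in this test), compound 1 gives 46000 nM
- compound 2, `Cc1ccc(C(=O)Nc2ncc(-c3ccccc3)o2)cc1`, compound 2 gives 26000 nM
- compound 3, `CCn1c(-c2ccc(OC)cc2)cnc1NC(=O)c1ccc(F)cc1`, compound 3 gives only a limit, > 100000 nM

Compound 1 holds the higher of the two numbers shown, though its gap to compound 2 lies within the scatter, so no order between them is claimed. The limit for compound 3 is one of the values shown (the limit of > 100000 nM in this assay, at which 1 of the 3 values shown sits).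

Compound 4, `Cn1c(-c2cccc(Cl)c2)cnc1NC(=O)c1ccc(F)cc1`, differs from compound 1 by 3-chlorophenyl in place of 4-bromophenyl on an aromatic carbon. Among the compounds with values here, no step between measured compounds is available for this change. The expected step of a 1.1-fold higher number from compound 1 to compound 4 (0.04 log units; within the scatter) is none beyond the scatter. Compound 4 is estimated at 50000 nM in this assay, with a range from 20000 nM to 120000 nM.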

Compound 4, half-maximal cytotoxic concentration: > 50000 nM
Compound 4: only a limit was reported; the forecaster's own chance of this, stated with the estimate: 25%; the middle value lies on the limit itself.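

In this assay, compound 4 gives only a limit, > 50000 nM. The step reads an at least 1.0-fold higher number from compound 1 to compound 4 (0.03 log units; that floor lies within the scatter), so 3-chlorophenyl in place of 4-bromophenyl on this aromatic carbon brings no lower number. How far the number rises cannot be read because compound 4 sits at a limit: the limit of > 50000 nM in this assay, at which 1 of the 4 values shown sits.

As far as these compounds go, the halogen and its ring position change together in this step, so their shares stay open; 3-bromophenyl or 4-chlorophenyl would separate them. Also open, from the compounds shown here alone, is whether an amine or a carboxylic acid on this phenyl ring would give a lower number.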